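The source may hold more compounds than are shown below. What is called first, only, known or untested is meant among the compounds shown, and "the series" means these compounds.

Measured compounds:
compound 1, `COc1ccc(-c2cc(NC(=O)COCC(=O)NCC(=O)NC3CCCCC3)nc(-c3ccc(OC)cc3)n2)cc1`, gives 21400 nM in an assay on HeLa cells for displacement of a labelled ligand from adenosine receptor A3 (Homo sapiens), read by fluorescence polarization, with a stated time of 30 min; on this read-out higher numbers stand for weaker inhibition and lower numbers for stronger inhibition;
compound 2, `COc1ccc(-c2cc(NC(=O)COCC(=O)NCC(=O)NCc3ccccc3)nc(-c3ccc(OC)cc3)n2)cc1`, gives 185000 nM in this assay;
compound 3, `COc1ccc(-c2cc(NC(=O)COCC(=O)N(C)CC(=O)NC3CCCCC3)nc(-c3ccc(OC)cc3)n2)cc1`, gives 23700 nM in this assay.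

Compound 4, `COc1ccc(-c2cc(NC(=O)COCC(=O)N(C)CC(=O)NCc3ccccc3)nc(-c3ccc(OC)cc3)n2)cc1`, has not yet been measured in this assay. It is related to compound 3 by one change, (benzyl in place of cyclohexyl on an amide-type nitrogen). The same change has already been made once among the measured compounds, from compound 1 to compound 2, (benzyl in place of cyclohexyl on an amide-type nitrogen), where it produced an 8.6-fold higher number from compound 1 to compound 2 (0.94 log units; beyond the scatter). The place of the change reads the same in both pairs, so this is the same change, not merely the same kind of change.

The cores of the two pairs differ in one respect, (methyl in place of hydrogen on an amide-type nitrogen). That difference by itself made a 1.1-fold higher number from compound 1 to compound 3 (0.04 log units; within the scatter), so compound 1 and compound 3 stand together within the scatter. Compound 2 and compound 3, which differ in both respects at once, are separated by a 7.8-fold lower number from compound 2 to compound 3 (0.89 log units; beyond the scatter).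

Because the earlier step of an 8.6-fold higher number from compound 1 to compound 2 (0.94 log units; beyond the scatter) was taken from a core that behaves like the core of compound 3, a step of similar size is expected here: an 8.0-fold higher number from compound 3 to compound 4 (0.90 log units; beyond the scatter) is the estimate for the move from compound 3 to compound 4. Within the data shown here, with only one earlier instance of the change to rest on, the range is kept wide. Compound 4 is therefore expected to give about 190000 nM in this assay, with a likely span from 70000 nM to 500000 nM.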

Compound 4, inhibition constant: 40100 nM
Estimate against measurement, compound 4: 4.7-fold (0.68 log units) above, outside the stated range (below it).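

In this assay, benzyl in place of cyclohexyl on an amide-type nitrogen gives a 1.7-fold higher number from compound 3 to compound 4 (0.23 log units; within the scatter), so on the core of compound 3, which carries the methyl, the change does not repeat its earlier step: the same change on two cores in this assay, an 8.6-fold higher number (0.94 log units; beyond the scatter) from compound 1 to compound 2 and a 1.7-fold higher number (0.23 log units; within the scatter) from compound 3 to compound 4, 5.1-fold (0.71 log units) apart, beyond the scatter of two such steps. Read the other way round, methyl in place of hydrogen on an amide-type nitrogen gives a 4.6-fold lower number from compound 2 to compound 4 (0.66 log units; beyond the scatter) in the benzyl pair, whereas the same change left the cyclohexyl pair within the scatter: the same change on two cores in this assay, a 1.1-fold higher number (0.04 log units; within the scatter) from compound 1 to compound 3 and a 4.6-fold lower number (0.66 log units; beyond the scatter) from compound 2 to compound 4, 5.1-fold (0.71 log units) apart, beyond the scatter of two such steps. The two changes therefore do not add independently across these four compounds, and a step measured on one core did not carry over to the other, but this single set of four compounds does not show why, nor whether the same holds for any other pair of groups.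

The compounds shown leave open whether a phenethyl or a cyclopentyl group on that amide-type nitrogen would follow the behaviour of benzyl or of cyclohexyl. They also leave open whether ethyl in place of the methyl would give the same result in the benzyl and cyclohexyl pairs.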